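The compounds below may be only part of what the source reports. "The series", "measured", "known", "first", "only" and "open" are said of these compounds alone.

Compound 1 `CC1OC(OC2CCCCC2OCCCC(C(=O)O)C(=O)O)C(O)C(O)C1O` opens the series. In a functional assay on HL-60 cells (Homo sapiens) for inhibition (a lower number here means a stronger inhibitor, a higher number a weaker inhibitor), compound 1 gives only a limit, > 5000000 nM. Compound 2 `CC1OC(OC2CCCCC2OCCCCC(C(=O)O)C(=O)O)C(O)C(O)C1O` carries the change (2,2-dicarboxyethyl in place of dicarboxymethyl on a saturated chain carbon, three bonds along the chain from an oxygen on a saturated carbon). In this assay compound 2 likewise gives only a limit, > 5000000 nM. The step that the two limits leave unreadable from compound 1 to compound 2 is thus not readable, since both values sit at the limit of > 5000000 nM in this assay, at which 2 of the 3 values shown sit. Compound 3 `CC1OC(OC2CCCCC2OC(=O)NCCCC(C(=O)O)C(=O)O)C(O)C(O)C1O` rests on another core; the difference between the two cores is not broken down here. In this assay, going by the values given here, compound 3 gives 1000000 nM, the only plain number among the three. Compound 4 `CC1OC(OC2CCCCC2OC(=O)NCCCCC(C(=O)O)C(=O)O)C(O)C(O)C1O` bears the same kind of change, (2,2-dicarboxyethyl in place of dicarboxymethyl on a saturated chain carbon, three bonds along the chain from an amide-type nitrogen), though here the place is three bonds along the chain from an amide-type nitrogen rather than from an oxygen on a saturated carbon. Because the earlier step that the two limits leave unreadable from compound 1 to compound 2 left no readable size, the expected step is small, a 2.0-fold higher number from compound 3 to compound 4 (0.30 log units; within the scatter). Compound 4 is accordingly estimated at 2000000 nM, between 500000 nM and 10000000 nM.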

Compound 4, half-maximal inhibitory concentration: 4000000 nM
For compound 4 the middle estimate is 2.0-fold (0.30 log units) below the measured one; measured number inside the range.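

In this assay, on the core of compound 3, putting 2,2-dicarboxyethyl in place of dicarboxymethyl gives a 4.0-fold higher number from compound 3 to compound 4 (0.60 log units; beyond the scatter), so on this core the change yields a weaker inhibitor. The same change on the core of compound 1 cannot be read, since both members of that pair give a limit and not a number: the limit of > 5000000 nM in this assay, at which 2 of the 4 values shown sit.

The change is therefore sized on one core only, and the compounds do not show whether its size or direction carries over to the other. Open, as far as these compounds go, is how a longer chain, such as 3,3-dicarboxypropyl or 4,4-dicarboxybutyl, would read on the core of compound 3. Also open, from the compounds shown here alone, is how a group with a single carboxylic acid, or a tetrazole, would read there.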